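This account rests on a few compounds, and the source may have more. Where it says the series, first, only, none or still open, it means among the compounds named here.

In a functional assay on U-251 cells (Homo sapiens) for inhibition, read by sulforhodamine B assay, with a stated time of 48 h, tested at 10 uM (on this read-out lower numbers stand for less inhibition and higher numbers for more inhibition at the one concentration tested (going by the name of the read-out)), compound 3 `COc1ccc(-c2cn3ccnc3c(-c3ccc4ncn(C5CCCCC5)c4c3)n2)cc1` gives 80.9%, the highest of the three numbers measured. Compound 2 `c1ccc(-c2cn3ccnc3c(-c3ccc4ncn(C5CCCCC5)c4c3)n2)cc1` gives 37.3% and compound 1 `Brc1cn2ccnc2c(-c2ccc3ncn(C4CCCCC4)c3c2)n1` gives 1.5%. The steps of a number 35.8 percentage points higher from compound 1 to compound 2 (beyond the scatter) and a number 79.4 percentage points higher from compound 1 to compound 3 (beyond the scatter) are both large, and the step of a number 43.6 percentage points higher from compound 2 to compound 3 (beyond the scatter) shows how much of that gain comes with the methoxy. Compound 4 `O=Cc1ccc(-c2cn3ccnc3c(-c3ccc4ncn(C5CCCCC5)c4c3)n2)cc1` differs from compound 3 by formyl in place of methoxy on an aromatic carbon. Among the compounds with values here, no measured step exchanges one such group for another; only the step of a number 43.6 percentage points higher from compound 2 to compound 3 (beyond the scatter) bears on it, and it shows that this position matters. Compound 4 is therefore expected to fall back toward compound 2, with an estimated step of a number 25.9 percentage points lower from compound 3 to compound 4 (beyond the scatter). Compound 4 is expected to give 55%, estimated between 25% and 85%.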

Compound 4, a percentage reported as inhibition, at one concentration (the size of the read-out at that concentration, not a potency): 32%
For compound 4 the middle estimate is 23 percentage points above the measured one, and the stated range covers the measured number.
By their numbers in this assay, from the lowest: compound 1; then compounds 4 and 2 (each within the scatter of the next); then compound 3.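

In this assay, the change from 4-methoxyphenyl to 4-formylphenyl gives a number 48.9 percentage points lower from compound 3 to compound 4 (beyond the scatter), so at this position the level reached with methoxy does not carry over to formyl, although both groups have the same heavy-atom count. Formyl and hydrogen cannot be told apart here, with a number 5.3 percentage points lower from compound 2 to compound 4 (within the scatter), while the 4-formylphenyl group still keeps a clear gain over bromo, with a number 30.5 percentage points higher from compound 1 to compound 4 (beyond the scatter). No available evidence explains the gap between methoxy and formyl. On these data alone, whether an amine, a hydroxy group or an ethoxy group at this place would match compound 3 stays open.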